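From (hydroxymethyl)carbonyl to isopropylcarbamoyl: compound 4

A few compounds are considered here, and "the series" means these few. Any claim that something is new, unique, unknown or untested is made for them only; others in the source may bear on it.

Measured so far:
compound 1 `O=C(Nc1ccc(S(=O)(=O)N2CCCCC2)c2ccccc12)c1ccccc1`: > 30000 nM
compound 2 `CCOC(=O)N1CCC(NS(=O)(=O)c2ccc(NCc3ccccc3)c3ccccc23)CC1`: 45.6 nM
compound 3 `Cc1ccccc1C(=O)Nc1ccc(S(=O)(=O)NC2CCN(C(=O)CO)CC2)c2ccccc12`: 5.4 nM

In an assay on L1.2 cells for binding affinity to C-C chemokine receptor type 8 (Homo sapiens) (a higher number here means a weaker inhibitor, a lower number a stronger inhibitor), compound 3 gives 5.4 nM, the lowest of the two numbers shown; compound 2 gives 45.6 nM, and the gap between the two is beyond the scatter. For compound 1 the assay reports only a limit, > 30000 nM.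

Compound 4 `Cc1ccccc1C(=O)Nc1ccc(S(=O)(=O)NC2CCN(C(=O)NC(C)C)CC2)c2ccccc12` differs from compound 3 in one place: isopropylamino in place of hydroxymethyl on a carbonyl carbon. The 1-((hydroxymethyl)carbonyl)piperidin-4-yl becomes 1-(isopropylcarbamoyl)piperidin-4-yl; the core and the remaining substituents are unchanged.

Among the measured compounds shown here, no measured pair shows this change. In this assay a step of a 1.5-fold higher number from compound 3 to compound 4 (0.17 log units; within the scatter) is expected, within the scatter. Compound 4 is estimated at 8 nM, with a range from 2 nM to 30 nM.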

Compound 4, inhibition constant: 77.7 nM
Compound 4: middle estimate off by 9.7-fold (0.99 log units), on the low side; measured number outside the range, above it.
By their numbers in this assay, from the lowest: compound 3; then compounds 2 and 4 (each within the scatter of the next). At a limit, above all of these: compound 1.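

Among the compounds shown here, the change from hydroxymethyl to isopropylamino on a carbonyl carbon gives a 14-fold higher number from compound 3 to compound 4 (1.16 log units; beyond the scatter) in this assay and is the first single-place comparison. The number therefore depends on the group at this carbonyl carbon, at least for these two groups, though one pair sets no trend. No measurement shown gives a cause for this step.

Open, on these data alone, is whether methylamino, with a shorter chain, or methoxymethyl at this carbon would track compound 3 or compound 4. Also open, as far as these compounds go, is how much of the step follows the entering nitrogen and how much the larger carbon chain.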